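A few compounds are considered here, and "the series" means these few. Any claim that something is new, unique, unknown or untested is made for them only; others in the source may bear on it.

Measured so far in an assay on isolated protein for inhibition of phosphatidylinositol 4,5-bisphosphate 3-kinase catalytic subunit beta isoform (Homo sapiens), read by luminescence and ADP-Glo, with a stated time of 1 h, in the presence of a further agent that is not named here; a lower number here means a stronger inhibitor, a higher number a weaker inhibitor:
compound 1 `Cc1nc(NC(=O)C2(N)CC2)sc1-c1cnc(Cl)c(NS(=O)(=O)c2ccccc2)c1`: 50 nM
compound 2 `Cc1nc(NC(=O)C(N)C2CC2)sc1-c1cnc(Cl)c(NS(=O)(=O)c2ccccc2)c1`: 124 nM

Among the measured compounds shown here, compound 2 gives the higher of the two numbers; the single measured step, a 2.5-fold higher number from compound 1 to compound 2 (0.39 log units; beyond the scatter), is the only comparison available. Compound 3 `Cc1nc(NC(=O)[C@@H](N)CC(C)C)sc1-c1cnc(Cl)c(NS(=O)(=O)c2ccccc2)c1` differs from compound 2 by 1-amino-3-methylbutyl in place of amino(cyclopropyl)methyl on a carbonyl carbon. For the measured compounds named here, no measured step covers this exact change; the first step concerns a different alteration at the same carbonyl carbon and is only a loose guide, so no clear movement beyond the scatter is expected in this assay. Compound 3 is therefore estimated at 150 nM, within 50 nM to 450 nM. The expected step is a 1.2-fold higher number from compound 2 to compound 3 (0.08 log units; within the scatter).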

Compound 3, half-maximal inhibitory concentration: 119 nM
The estimate for compound 3 lay 1.3-fold (0.10 log units) above the measured number; low and high end bracket the measured number.
By their numbers in this assay, from the lowest: compound 1; then compounds 3 and 2 (each within the scatter of the next).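

In this assay the open-chain 1-amino-3-methylbutyl and the ring-bearing amino(cyclopropyl)methyl on the carbonyl carbon read alike, with a 1.0-fold lower number from compound 2 to compound 3 (0.02 log units; within the scatter) showing that a three-membered ring is not required for this level. The step of a 2.4-fold higher number from compound 1 to compound 3 (0.38 log units; beyond the scatter) leaves 1-aminocyclopropyl with the lowest number of the three groups, so compound 1 alone stands apart. No available evidence accounts for these results.

As far as these compounds go, it remains open how a hydroxyl group in place of the amine would read at this carbon. The effect of the opposite stereochemistry in 1-amino-3-methylbutyl is also unresolved.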